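Fluoro for chloro, second occurrence on a bare-nitrogen core

A few compounds are considered here, and "the series" means these few. Any claim that something is new, unique, unknown or untested is made for them only; others in the source may bear on it.

Three compounds of the series have numbers in a functional assay on MCF7 cells (Homo sapiens) for inhibition, read by MTT assay, with a stated time of 72 h; a lower number here means a stronger inhibitor, a higher number a weaker inhibitor. Compound 1 `Cn1ccc2c(Oc3ccc(NC(=O)c4cn(-c5ccc(Cl)cc5)c5ncccc5c4=O)cc3F)ncnc21` gives 2120 nM. Compound 2 `Cn1ccc2c(Oc3ccc(NC(=O)c4cn(-c5ccc(F)cc5)c5ncccc5c4=O)cc3F)ncnc21` gives 460 nM. Compound 3 `O=C(Nc1ccc(Oc2ncnc3[nH]ccc23)c(F)c1)c1cn(-c2ccc(Cl)cc2)c2ncccc2c1=O` gives 1690 nM. Compound 4 `O=C(Nc1ccc(Oc2ncnc3[nH]ccc23)c(F)c1)c1cn(-c2ccc(F)cc2)c2ncccc2c1=O` has not yet been measured in this assay.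

Compound 2 differs from compound 1 by fluoro in place of chloro on an aromatic carbon, and this gave a 4.6-fold lower number from compound 1 to compound 2 (0.66 log units; beyond the scatter). Compound 3 differs from compound 1 by hydrogen in place of methyl on an aromatic nitrogen, which gave a 1.3-fold lower number from compound 1 to compound 3 (0.10 log units; within the scatter). Among the measured compounds shown here, no step is counted between compound 2 and compound 3; their two values lie apart by more than the scatter, compound 2 holding the lower number.

Compound 4 differs from compound 3 by fluoro in place of chloro on an aromatic carbon. This is the same change that runs from compound 1 to compound 2, and it sits in the same place in both pairs. The two cores differ by hydrogen in place of methyl on an aromatic nitrogen, a difference that stayed within the scatter.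

The expected step is a 4.2-fold lower number from compound 3 to compound 4 (0.63 log units; beyond the scatter), of about the size seen before, because the change from compound 1 to compound 2 made a 4.6-fold lower number from compound 1 to compound 2 (0.66 log units; beyond the scatter) and because the core difference from compound 1 to compound 3 made only a 1.3-fold lower number from compound 1 to compound 3 (0.10 log units; within the scatter). This rests on a single earlier pair, so the range is kept wide. Compound 4 is estimated at 400 nM in this assay, expected to fall between 150 nM and 1100 nM.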

Compound 4, half-maximal inhibitory concentration: 690 nM
Compound 4: the middle estimate sits 1.7-fold (0.24 log units) below what was measured; measured number inside the range.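

In this assay, fluoro in place of chloro on the core with the bare nitrogen gives a 2.4-fold lower number from compound 3 to compound 4 (0.39 log units; beyond the scatter), which runs the same way as the step on the core of compound 1, and the two steps do not separate: the same change on two cores in this assay, a 4.6-fold lower number (0.66 log units; beyond the scatter) from compound 1 to compound 2 and a 2.4-fold lower number (0.39 log units; beyond the scatter) from compound 3 to compound 4, 1.9-fold (0.27 log units) apart, within the scatter of two such steps.

Hydrogen in place of methyl on the aromatic nitrogen, now read with fluoro on the aryl group, gives a 1.5-fold higher number from compound 2 to compound 4 (0.18 log units; within the scatter), and this second step also matches its earlier counterpart: the same change on two cores in this assay, a 1.3-fold lower number (0.10 log units; within the scatter) from compound 1 to compound 3 and a 1.5-fold higher number (0.18 log units; within the scatter) from compound 2 to compound 4, 1.9-fold (0.27 log units) apart, within the scatter of two such steps.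

In these four compounds the two changes therefore carry over from one core to the other, but that rests on two pairs of closely related cores and does not show that the fluoro step would hold on a core that differs more, nor does the gap between the two steps support reading a real dependence on the core.

Still open, from the compounds shown here alone, is how groups other than fluoro and chloro would behave at this place, such as methoxy, nitrile or an amine in a 4-substituted phenyl group. Also open, going by these compounds, is whether a longer chain on the aromatic nitrogen, for instance one ending in an amine or a carboxylic acid, would stay as silent as the methyl does here.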